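From Iodo to Ethoxy on a Shared Core

The source may hold more compounds than are shown below. What is called first, only, known or untested is meant among the compounds shown, and "the series" means these compounds.

Three compounds share one core and differ only in the halogen on a saturated ring carbon. In a functional assay on HT-29 cells (Homo sapiens) for cytotoxicity, read by MTT assay (a higher number here means a weaker inhibitor, a lower number a stronger inhibitor), compound 1 `C=C1C(=O)[C@]23C[C@@]1(Cl)CC[C@H]2[C@@]12C=CC(=O)[C@](C)(C(=O)O1)[C@H]2[C@@H]3C(=O)OCc1ccccc1`, the chloro member, gives 4500 nM. The fluoro member, compound 2 `C=C1C(=O)[C@]23C[C@@]1(F)CC[C@H]2[C@@]12C=CC(=O)[C@](C)(C(=O)O1)[C@H]2[C@@H]3C(=O)OCc1ccccc1`, gives 59100 nM, and the iodo member, compound 3 `C=C1C(=O)[C@]23C[C@@]1(I)CC[C@H]2[C@@]12C=CC(=O)[C@](C)(C(=O)O1)[C@H]2[C@@H]3C(=O)OCc1ccccc1`, gives 50200 nM. Compound 3 therefore stands level with the fluoro member, as a 1.2-fold lower number from compound 2 to compound 3 (0.07 log units; within the scatter) shows, and well apart from the chloro member, as an 11-fold higher number from compound 1 to compound 3 (1.05 log units; beyond the scatter) shows. The third step, a 13-fold higher number from compound 1 to compound 2 (1.12 log units; beyond the scatter), is just as large.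

Compound 4 `C=C1C(=O)[C@]23C[C@@]1(OCC)CC[C@H]2[C@@]12C=CC(=O)[C@](C)(C(=O)O1)[C@H]2[C@@H]3C(=O)OCc1ccccc1` carries ethoxy in place of iodo on a saturated ring carbon. Within the data shown here, no ethoxy compound has yet been measured, so only these halogen steps bear on the change. They show that this carbon can tolerate a large step, yet two of the three replacements leave the number at the same high level. Only compound 1, at 4500 nM, goes against that level. In this assay the expected change is therefore small, and the estimated step is a 1.7-fold lower number from compound 3 to compound 4 (0.22 log units; within the scatter), with a large drop still possible. For compound 4 the estimate is 30000 nM, with an expected range from 8000 nM to 80000 nM.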

Compound 4, half-maximal inhibitory concentration: 23300 nM
Estimate against measurement, compound 4: 1.3-fold (0.11 log units) above; measured number inside the range.
By their numbers in this assay, from the lowest: compound 1; then compound 4; then compounds 3 and 2 (each within the scatter of the next).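

Ethoxy is the only group shown on this saturated ring carbon that is not a halogen, and it does not fall on either of the levels the halogens occupy. In this assay compound 4 sits apart from the iodo and fluoro members (a 2.2-fold lower number from compound 3 to compound 4 (0.33 log units; beyond the scatter); a 2.5-fold lower number from compound 2 to compound 4 (0.40 log units; beyond the scatter)) but does not reach the chloro member (a 5.2-fold higher number from compound 1 to compound 4 (0.71 log units; beyond the scatter)), so the position holds an intermediate level as well as the high level of compounds 2 and 3 and the low one of compound 1, and compound 1 remains the strongest of the four. No measurement shown here explains why ethoxy lands at this level or why the chloro member stands apart from every other group, and the role of the hydrogen-bond acceptor that ethoxy brings in therefore cannot be judged.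

The compounds shown leave open where bromo would fall, and so whether the low number of compound 1 belongs to chloro alone or extends to a second halogen. They also leave open whether a hydroxyl group, an amine or a chain longer than ethoxy would stay at the intermediate level or move away from it.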